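The source may report more compounds than this note shows. Statements on the series, on what has been measured and on what is new or still open speak of the compounds shown alone.

Notes on the amide series. Compound 1 `O=C(Nc1cc(Oc2ccc(Nc3nccc4[nH]cc(-c5ccc(F)cc5)c(=O)c34)cc2F)ccn1)C1CC1` gives 81.8% in a functional assay on MKN-45 cells (Homo sapiens) for antiproliferative activity, read by MTT assay, with a stated time of 72 h, tested at 10 uM; on this read-out lower numbers stand for less inhibition and higher numbers for more inhibition at the one concentration tested (going by the name of the read-out). Compound 2 `CC(O)C(=O)Nc1cc(Oc2ccc(Nc3nccc4[nH]cc(-c5ccc(F)cc5)c(=O)c34)cc2F)ccn1` gives 67.3% in this assay, and compound 3 `CCCCC(=O)Nc1cc(Oc2ccc(Nc3nccc4[nH]cc(-c5ccc(F)cc5)c(=O)c34)cc2F)ccn1` gives 62.7% in this assay. Compound 3 carries the lowest of the three numbers, though its gap to compound 2, a number 4.6 percentage points lower from compound 2 to compound 3 (within the scatter), is within the scatter; only the gap to compound 1, a number 19.1 percentage points lower from compound 1 to compound 3 (beyond the scatter), is beyond it.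

Compound 4 `CC(C)(C)C(=O)Nc1cc(Oc2ccc(Nc3nccc4[nH]cc(-c5ccc(F)cc5)c(=O)c34)cc2F)ccn1` brings the change (tert-butyl in place of butyl on a carbonyl carbon). Among the measured compounds shown here, no measured step swaps butyl for tert-butyl, so the only steps that bear on it are those at the same carbonyl carbon: a number 14.5 percentage points lower from compound 1 to compound 2 (beyond the scatter), a number 19.1 percentage points lower from compound 1 to compound 3 (beyond the scatter) and a number 4.6 percentage points lower from compound 2 to compound 3 (within the scatter). Together they show that both open-chain groups stand below cyclopropyl, with no separation between the two of them. The tert-butyl group is new to the set, so the expected step is a number 5.3 percentage points higher from compound 3 to compound 4 (within the scatter), most likely within the scatter and, if anything, upward. Compound 4 is therefore estimated at 68% in this assay, with a range from 52% to 82%.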

Compound 4, a percentage reported as inhibition, at one concentration (the size of the read-out at that concentration, not a potency): 62.5%
Estimate against measurement, compound 4: 5.5 percentage points above, within the range that was stated.
By their numbers in this assay, from the lowest: compounds 4, 3 and 2 (each within the scatter of the next); then compound 1.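

The branched tert-butyl group gives no separation from the straight butyl chain on this carbonyl carbon in this assay (a number 0.2 percentage points lower from compound 3 to compound 4 (within the scatter)), nor from 1-hydroxyethyl (a number 4.8 percentage points lower from compound 2 to compound 4 (within the scatter)). Cyclopropyl remains apart from this new group as well (a number 19.3 percentage points lower from compound 1 to compound 4 (beyond the scatter)), so compound 2, compound 3 and compound 4 form a single level below compound 1, and among these three groups, branching of the four-carbon chain makes no readable difference. Nothing at hand explains why compound 1 stands apart from the other three.

Open, from the compounds shown here alone, is whether cyclobutyl or cyclopentyl on the same carbonyl carbon would stay with compound 1 or join the lower level. Equally open, going by these compounds, is what an aminomethyl group, a carboxylic acid or a longer chain would give at this position.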